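Piperazine in place of the dipropargylamine

The compounds below may be only part of what the source reports. "The series", "measured", "known", "first", "only" and "open" are said of these compounds alone.

compound 1 `C#CCN(CCCC)Cc1cn(-c2cc(NC(=S)NCC)ncn2)cn1` — > 50000 nM
compound 2 `C#CCN(CC#C)Cc1cn(-c2cc(NC(=S)NCC)ncn2)cn1` — > 50000 nM

In an assay on isolated protein for inhibition of Amine oxidase [flavin-containing] B (Homo sapiens), read by fluorescence and Amplex Red, with a stated time of 15 min (a lower number here means a stronger inhibitor, a higher number a weaker inhibitor), compound 1 returns only a limit, > 50000 nM. Compound 2 also returns only a limit, > 50000 nM. The step that the two limits leave unreadable from compound 1 to compound 2 is therefore unreadable, because both values sit at the limit of > 50000 nM in this assay, at which 2 of the 2 values shown sit. Compound 3 `C#CCN1CCN(Cc2cn(-c3cc(NC(=S)NCC)ncn3)cn2)CC1` carries 4-propargylpiperazin-1-yl in place of dipropargylamino on a saturated chain carbon bound to an aromatic carbon. Within the data shown here, no measured step gives a readable size, so no direction beyond the scatter is expected for this change. Compound 3 is estimated at 60000 nM in this assay, in the range 15000 nM to 250000 nM. The expected step is a step that the limit leaves unreadable from compound 2 to compound 3.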

Compound 3, half-maximal inhibitory concentration: > 50000 nM
Compound 3 was reported as a limit; the forecaster's own chance of this, stated with the estimate: 70%; the middle value does not contradict the limit.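

Among these compounds, no step among compound 1, compound 2 and compound 3 can be read, as each value is only a limit of the assay: the limit of > 50000 nM in this assay, at which 3 of the 3 values shown sit.

The compounds shown leave open whether dipropargylamino and 4-propargylpiperazin-1-yl differ at all in this assay.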